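From 4-chlorophenyl to 2-methoxyphenyl: expected effect on compound 3

The compounds below may be only part of what the source reports. "The series", "measured", "known", "first", "only" and "open" are said of these compounds alone.

In a functional assay on HT-1080 cells (Homo sapiens) for cytotoxicity, read by MTT assay, with a stated time of 72 h (on this read-out higher numbers stand for weaker inhibition and lower numbers for stronger inhibition), compound 1 (`COc1ccc(/C=C2\CCC/C(=C\c3ccccc3Cl)C2=O)cc1OC`) gives 6800 nM and compound 2 (`COc1ccc(/C=C2\CCC/C(=C\c3ccc(Cl)cc3)C2=O)cc1OC`) gives 4800 nM with the two values inside the scatter of each other. Going by the values given here, the one measured step at this place is a 1.4-fold lower number from compound 1 to compound 2 (0.15 log units; within the scatter) and it bears directly on the next change. Compound 3 (`COc1ccccc1/C=C1\CCC/C(=C\c2ccc(OC)c(OC)c2)C1=O`) follows from compound 2 through 2-methoxyphenyl in place of 4-chlorophenyl on a double-bonded chain carbon bound to a double-bonded ring carbon at that same place. Among the compounds with values here, no measured step covers a methoxy group there, so no shift beyond the scatter is expected. The expected step is a 1.1-fold higher number from compound 2 to compound 3 (0.06 log units; within the scatter) with no firm direction. For compound 3 the estimate is 5500 nM with an expected range from 2500 nM to 12000 nM in this read-out.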

Compound 3, half-maximal inhibitory concentration: 8100 nM
Beside the measured number, compound 3's estimate is 1.5-fold (0.17 log units) below it; the range from low to high includes it.
By their numbers in this assay, from the lowest: compounds 2, 1 and 3 (each within the scatter of the next).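

In this assay, 2-methoxyphenyl in place of 4-chlorophenyl on a double-bonded chain carbon bound to a double-bonded ring carbon gives a step inside the scatter (a 1.7-fold higher number from compound 2 to compound 3 (0.23 log units; within the scatter)), and methoxy in place of chloro on an aromatic carbon does the same (a 1.2-fold higher number from compound 1 to compound 3 (0.08 log units; within the scatter)). This place therefore now carries a methoxy group as well as chloro with no readable shift, so the three compounds cannot be ordered. Nothing available explains this flat result.

Going by these compounds, whether 4-methoxyphenyl, or an amine or carboxylic acid on this ring, would shift the number beyond the scatter remains open.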